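This account rests on a few compounds, and the source may have more. Where it says the series, first, only, none or still open, it means among the compounds named here.

Going by the values given here, in an ADME assay on HEp-2 cells (Homo sapiens) for cytotoxicity (a higher number here means that more compound is tolerated, a lower number that less compound is tolerated), two compounds have numbers so far. Compound 1 `CC(C)CCn1c(Cn2c(=O)n(C(C)C)c3ccccc32)nc2cc(CNC3CC3)ccc21` gives 17200 nM and stands as the higher of the two, while compound 2 `C=C(C)n1c(=O)n(Cc2nc3cc(/C(N)=N\O)ccc3n2CCC(C)C)c2ccccc21` gives 3470 nM and lies lower by a gap beyond the usual scatter. These two differ in more than one place, so their gap ties to no single change. Compound 3 `CC(C)CCn1c(Cn2c(=O)n(C(C)C)c3ccccc32)nc2cc(CF)ccc21` is still unmeasured. It keeps the rest of compound 1 and has fluoro in place of cyclopropylamino on a saturated chain carbon bound to an aromatic carbon. Among the compounds with values here, no measured pair shows this change, so the expectation rests on compound 1 alone at 17200 nM and stays loose. In this assay no step beyond the scatter is expected, and neither direction can be favoured. The estimated move is a 1.1-fold higher number from compound 1 to compound 3 (0.04 log units; within the scatter) and it carries that same uncertainty. For compound 3 the estimated value is 19000 nM with an expected range from 6500 nM to 60000 nM as the likely span.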

Compound 3, half-maximal cytotoxic concentration: 37300 nM
Beside the measured number, compound 3's estimate is 2.0-fold (0.29 log units) below it; the measured number falls inside the stated range.
By their numbers in this assay, from the lowest: compound 2; then compound 1; then compound 3.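

In this assay, the step at this position is a 2.2-fold higher number from compound 1 to compound 3 (0.34 log units; beyond the scatter), a modest move beyond the usual scatter. Going by these compounds alone, it gives the first reading of a single change, since compound 1 and compound 2 differ in more than one place and their gap could not be tied to any one of them. The move from (cyclopropylamino)methyl to fluoromethyl, on a saturated chain carbon bound to an aromatic carbon, removes the three-membered ring and the nitrogen with its hydrogen-bond donor and acceptor, and the number does not drop, though nothing measured here says why the number changes.

On these data alone, this one pair cannot separate the loss of the cyclopropylamino group from the arrival of fluoro, so it remains open whether a plain methyl, a hydroxymethyl or an open-chain amine such as isopropylamino at this place would give a similar number. As far as these compounds go, it also remains open whether the same change would give a step of this size on the core of compound 2.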